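Swapping the Pyridazine Amide for a Methylpiperidine Amide

The source may hold more compounds than are shown below. What is called first, only, known or untested is meant among the compounds shown, and "the series" means these compounds.

Compound 1 `CCCn1c(NC(=O)c2cccnn2)nc2cc(C(N)=O)cc(OC)c21` carries a plain propyl chain on the aromatic nitrogen of the shared core. In an assay for activation of interferon regulatory factor 3 (Homo sapiens), read by a luciferase reporter, with a stated time of 20 h (a lower number here means that less compound is needed, a higher number that more compound is needed for the effect), compound 1 reaches only a limit, > 100000 nM. Compound 2 `COc1cc(C(N)=O)cc2nc(NC(=O)c3cccnn3)n(CCCNC(=O)OCc3ccccc3)c12` adds a (benzyloxycarbonyl)amino group to that chain. In this assay compound 2 likewise gives only a limit, > 100000 nM. Both values sit at the limit of > 100000 nM in this assay, at which 2 of the 2 values shown sit, and the step that the two limits leave unreadable from compound 1 to compound 2 cannot be read for that reason. Compound 2 therefore stands at the same limit as compound 1, with no number to rank it.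

Compound 3 `COc1cc(C(N)=O)cc2nc(NC(=O)C3CCN(C)CC3)n(CCCNC(=O)OCc3ccccc3)c12` differs from compound 2 at the carbonyl carbon: 1-methylpiperidin-4-yl in place of pyridazin-3-yl on a carbonyl carbon. Going by the values given here, no measured step touches this position; the single measured step concerns the chain on the aromatic nitrogen, and its size is not readable. Nothing in the two measured values points to a gain in this assay. Compound 3 is therefore expected to remain near the limit, at an estimated 100000 nM within a range of 30000 nM to 300000 nM. The expected step of a number no higher from compound 2 to compound 3 (the limit leaves the size open) is accordingly estimated as none beyond the scatter.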

Compound 3, half-maximal effective concentration: > 100000 nM
Compound 3 was reported as a limit; the forecaster's own chance of this, stated with the estimate: 75%; the middle value sits exactly at the limit.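

In this assay compound 3 gives > 100000 nM as a limit and not a number. Going by these compounds alone, no step from compound 2 to compound 3 can be read, since both stand at the same limit: the limit of > 100000 nM in this assay, at which 3 of the 3 values shown sit. The compounds shown leave open whether any of these structures reaches a measurable effect, and how 1-methylpiperidin-4-yl and pyridazin-3-yl compare on that carbonyl carbon.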